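Swapping one halogen for another at the phenoxy ring

The source may report more compounds than this note shows. Statements on the series, on what has been measured and on what is new or still open speak of the compounds shown alone.

Two compounds share a core and differ only in the group carried on the oxygen-linked ring. Compound 1 `COc1ccccc1Oc1nc(Nc2ccc(C#N)cc2)nc2ccccc12` gives 150000 nM in an ADME assay on MT4 cells (Homo sapiens) for cytotoxicity, read by MTT assay, with a stated time of 4 days; on this read-out lower numbers stand for higher toxicity in this test and higher numbers for lower toxicity in this test. Compound 2 `N#Cc1ccc(Nc2nc(Oc3ccc(Cl)cc3)c3ccccc3n2)cc1` gives 198000 nM in the same test. Compound 2 stands highest of the two numbers, with compound 1 nearest; the step of a 1.3-fold higher number from compound 1 to compound 2 (0.12 log units; within the scatter) lies within the scatter, so the two read as alike.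

Compound 3 `N#Cc1ccc(Nc2nc(Oc3ccc(Br)cc3)c3ccccc3n2)cc1` is the next step, differing from compound 2 by bromo in place of chloro on an aromatic carbon. Among the measured compounds shown here, only one measured step exists, and it changed the whole group on the oxygen rather than a single halogen; it moved nothing beyond the scatter. On that basis, and with the change from chloro to bromo small, no step beyond the scatter is expected for compound 3 in this assay, so its estimated step is a 1.0-fold higher number from compound 2 to compound 3 (0.00 log units; within the scatter). The expected value for compound 3 is 200000 nM, within a range from 100000 nM to 400000 nM.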

Compound 3, half-maximal cytotoxic concentration: 215000 nM
Estimate against measurement, compound 3: 1.1-fold (0.03 log units) below; the range from low to high includes it.
By their numbers in this assay, from the lowest: compounds 1, 2 and 3 (each within the scatter of the next).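

The change of a single atom on the phenoxy ring gives a 1.1-fold higher number from compound 2 to compound 3 (0.04 log units; within the scatter) in this assay, so chloro and bromo at this place on the ring read as alike in this test. The larger change of the whole group on the oxygen gives a 1.4-fold higher number from compound 1 to compound 3 (0.16 log units; within the scatter) and also stays within the scatter, which means that all three groups seen so far on this oxygen read as alike here. Nothing available bears on why this read-out stays so close across these compounds.

The compounds shown leave open whether an amine or a carboxylic acid in place of the halogen would move the number beyond the scatter. They also leave open whether a smaller halogen, fluoro, would read like chloro and bromo.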